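The source may report more compounds than this note shows. Statements on the series, on what has been measured and on what is new or still open speak of the compounds shown alone.

Of the compounds shown here, three built on one shared core have been tested in a functional assay on the whole organism (strain Wister albino) for inhibition, with Rattus norvegicus as the target, read by paw edema, with stated times of 30 min and 3 h, at a dose of 10 mg/kg by the oral route; on this read-out lower numbers stand for less inhibition and higher numbers for more inhibition at the one dose given (going by the name of the read-out). Compound 1 `CCOC(=O)C1CCN(Cn2nc(Cc3ccc(SC)cc3)oc2=S)CC1` gives 57.4% in this assay, compound 2 `CC(C)Cc1ccc(C(C)c2nn(CN3CCN(c4ccc(F)cc4)CC3)c(=S)o2)cc1` gives 75.4%, and compound 3 `COc1ccc(N2CCN(Cn3nc(Cc4ccc(SC)cc4)oc3=S)CC2)cc1` gives 33.7%, the lowest of the three; its nearest neighbour is compound 1, and the gap to each of the other two lies beyond the scatter. Compound 4 `CCOc1ccccc1N1CCN(Cn2nc(Cc3ccc(SC)cc3)oc2=S)CC1` has not yet been measured. It differs from compound 3 in one place: 2-ethoxyphenyl in place of 4-methoxyphenyl on an amine nitrogen in a ring. For the measured compounds named here, no measured pair shows what this swap does, so the expectation rests on compound 3 alone. The expected step of a number 6.3 percentage points higher from compound 3 to compound 4 (within the scatter) is small, likely within the scatter, with a slight lean upward. Compound 4 is therefore expected to give 40% in this assay, between 25% and 58%.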

Compound 4, a percentage reported as inhibition, in the whole organism at one dose (the size of the read-out at that dose, not a potency): 42.5%
Compound 4: middle estimate off by 2.5 percentage points, on the low side; low and high end bracket the measured number.
By their numbers in this assay, from the lowest: compounds 3 and 4 (each within the scatter of the next); then compound 1; then compound 2.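

In this assay the swap to 2-ethoxyphenyl from 4-methoxyphenyl on an amine nitrogen in a ring gives a number 8.8 percentage points higher from compound 3 to compound 4 (within the scatter) and so leaves the two compounds indistinguishable. For the compounds shown here, this is the first reading of a change at this position, and here a different alkoxy chain at a different ring position on the phenyl group gives no clear separation. Nothing available explains this result. Still open, from the compounds shown here alone, is what 2-methoxyphenyl would show, which would separate the effect of chain length from that of ring position. Also open, going by these compounds, is whether an amine or a carboxylic acid on this phenyl ring would move the number beyond the scatter.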